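Methyl in Place of Hydrogen: Compound 2 to Compound 3

This account rests on a few compounds, and the source may have more. Where it says the series, first, only, none or still open, it means among the compounds named here.

Within the data shown here, compound 2 `CCOC(=O)c1cnc(NN2C(=O)C=C(C)C2=O)nc1-c1ccsc1` gives 200 nM in a functional assay on Jurkat cells (Homo sapiens) for inhibition (on this read-out lower numbers stand for stronger inhibition and higher numbers for weaker inhibition), the lowest of the two numbers known here; its nearest neighbour, compound 1 `CCOC(=O)c1cnc(NN2C(=O)C=C(C)C2=O)nc1C(F)(F)F`, gives 2000 nM in this assay. Among the measured compounds shown here, the only measured step is a 10-fold lower number from compound 1 to compound 2 (1.00 log units; beyond the scatter), a change at a different place on the shared core. Compound 3 `CCOC(=O)c1cnc(N(C)N2C(=O)C=C(C)C2=O)nc1-c1ccsc1` differs from compound 2 by methyl in place of hydrogen on a nitrogen on an aromatic ring. For the measured compounds named here, no measured pair in this set alters that nitrogen, so the step from compound 1 to compound 2 offers no guide to the direction or size of the change in this assay. With nothing to anchor it, a modest weakening is expected and the estimate carries a wide range. For compound 3 the expected result in this assay is 600 nM, a step of a 3.0-fold higher number from compound 2 to compound 3 (0.48 log units; beyond the scatter), with a range from 120 nM to 3000 nM.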

Compound 3, half-maximal inhibitory concentration: 120 nM
Beside the measured number, compound 3's estimate is 5.0-fold (0.70 log units) above it; the range from low to high includes it.
By their numbers in this assay, from the lowest: compounds 3 and 2 (each within the scatter of the next); then compound 1.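

In this assay, methyl in place of hydrogen on this nitrogen gives a 1.7-fold lower number from compound 2 to compound 3 (0.22 log units; within the scatter), so compound 2 and compound 3 cannot be told apart on this read-out. Among these compounds, this is the first measured change at this nitrogen, and it shows that the hydrogen there can be replaced by methyl without a change beyond the scatter, at least while thiophen-3-yl stays in place on the shared core. Nothing measured here explains this result.

On these data alone, whether a longer chain such as ethyl, or a group carrying an amine or a carboxylic acid, would be tolerated on this nitrogen remains open. As far as these compounds go, it is also open whether methyl at this nitrogen would give a similar result with trifluoromethyl in place of thiophen-3-yl, as in compound 1.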